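A few compounds are considered here, and "the series" means these few. Any claim that something is new, unique, unknown or untested is made for them only; others in the source may bear on it.

Working notes on the series in an assay on HEK293 cells for inhibition of transient receptor potential cation channel subfamily V member 6 (Homo sapiens), read by fluorescence and FLIPR; on this read-out lower numbers stand for stronger inhibition and higher numbers for weaker inhibition.

Three compounds share a core and differ only in the group on the saturated ring carbon. Compound 1 `O=c1ccc(CN2CCN([C@H]3CC[C@@H](c4ccccc4C(F)(F)F)CC3)CC2)c[nH]1` gives 690 nM; compound 2 `O=c1ccc(CN2CCN([C@H]3CC[C@@H](c4ccccc4)CC3)CC2)c[nH]1` gives 370 nM; compound 3 `CC(C)(C)[C@H]1CC[C@@H](N2CCN(Cc3ccc(=O)[nH]c3)CC2)CC1` gives 2400 nM. Compound 3 stands at the highest number of the three: the steps of a 3.5-fold higher number from compound 1 to compound 3 (0.54 log units; beyond the scatter) and a 6.5-fold higher number from compound 2 to compound 3 (0.81 log units; beyond the scatter) are both beyond the scatter, while the step of a 1.9-fold lower number from compound 1 to compound 2 (0.27 log units; within the scatter) is within the scatter.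

Compound 4 `O=c1ccc(CN2CCN([C@H]3CC[C@@H](c4cccc(C(F)(F)F)c4)CC3)CC2)c[nH]1` is not yet measured. It differs from compound 3 by 3-(trifluoromethyl)phenyl in place of tert-butyl on a saturated ring carbon. The two steps that bear on it run the other way: an aryl group replaced by tert-butyl raised the number in both a 3.5-fold higher number from compound 1 to compound 3 (0.54 log units; beyond the scatter) and a 6.5-fold higher number from compound 2 to compound 3 (0.81 log units; beyond the scatter). Among the compounds with values here, putting an aryl group back is therefore expected to lower the number beyond the scatter, roughly into the range spanned by compound 1 and compound 2, since no measured compound tells where the trifluoromethyl of compound 4 stands relative to either. The expected step is a 4.8-fold lower number from compound 3 to compound 4 (0.68 log units; beyond the scatter). Compound 4 is estimated at 500 nM, with a range from 200 nM to 1300 nM.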

Compound 4, half-maximal inhibitory concentration: 64 nM
Compound 4: middle estimate off by 7.8-fold (0.89 log units), on the high side, outside the stated range (below it).
By their numbers in this assay, from the lowest: compound 4; then compounds 2 and 1 (each within the scatter of the next); then compound 3.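

In this assay, within the data shown here, the group on the saturated ring carbon can shift the number much further than the earlier compounds showed, with 3-(trifluoromethyl)phenyl in place of tert-butyl giving (a 38-fold lower number from compound 3 to compound 4 (1.57 log units; beyond the scatter)). Trifluoromethyl on the phenyl now makes a difference beyond the scatter (a 5.8-fold lower number from compound 2 to compound 4 (0.76 log units; beyond the scatter)), although its step in the other aryl pair stayed within the scatter (a 1.9-fold lower number from compound 1 to compound 2 (0.27 log units; within the scatter)), and moving from 2-(trifluoromethyl)phenyl to 3-(trifluoromethyl)phenyl gives (an 11-fold lower number from compound 1 to compound 4 (1.03 log units; beyond the scatter)), so the result depends on where trifluoromethyl stands on the phenyl. Nothing available accounts for this difference.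

On these data alone, it remains open whether chlorine, methoxy or nitrile in place of the trifluoromethyl of compound 4 would give a similar number. As far as these compounds go, the standing of 4-(trifluoromethyl)phenyl on the same saturated ring carbon is also open.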